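A Chloro Substituent Tested on a Weak Growth Inhibitor

A few compounds are considered here, and "the series" means these few. Any claim that something is new, unique, unknown or untested is made for them only; others in the source may bear on it.

Compound 1 `Oc1ccc(O)c(-c2cc(-c3ccc(Cl)cc3)nn2-c2ccccc2)c1`: 60400 nM
Compound 2 `NS(=O)(=O)c1ccc(-n2nc(-c3ccccc3)cc2-c2cc(O)ccc2O)cc1`: 98200 nM

In a functional assay on cells (Cancer cell lines, Homo sapiens) for cytotoxicity, read by sulforhodamine B assay, with a stated time of 48 h (a higher number here means a weaker inhibitor of growth, a lower number a stronger inhibitor of growth), compound 2 gives the higher of the two numbers, yet its gap to compound 1 lies within the scatter, so the two compounds stand level. Compound 3 `NS(=O)(=O)c1ccc(-n2nc(-c3ccc(Cl)cc3)cc2-c2cc(O)ccc2O)cc1` differs from compound 2 in one place: chloro in place of hydrogen on an aromatic carbon. Going by the values given here, no measured pair shows this change, so its effect is unknown here; a step within the scatter, in either direction, is expected. Compound 3 is therefore estimated at 75000 nM, with a range from 30000 nM to 190000 nM, an expected step of a 1.3-fold lower number from compound 2 to compound 3 (0.12 log units; within the scatter).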

Compound 3, concentration for total growth inhibition: 50900 nM
Estimate against measurement, compound 3: 1.5-fold (0.17 log units) above, within the range that was stated.
By their numbers in this assay, from the lowest: compounds 3, 1 and 2 (each within the scatter of the next).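

In this assay, chloro in place of hydrogen on the aromatic carbon para to a large group gives a 1.9-fold lower number from compound 2 to compound 3 (0.29 log units; within the scatter) and so leaves compound 3 level with compound 2 at this position. With that chloro present, a sulfamoyl group as the one difference gives a 1.2-fold lower number from compound 1 to compound 3 (0.07 log units; within the scatter) and so also produces no step beyond the scatter. No measurement bearing on these results is available to explain them. Going by these compounds, whether an amine, a carboxylic acid or a longer chain at the chloro position would shift growth inhibition beyond the scatter remains open.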